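Amide series: piperidinyl replacement on the shared core

This account rests on a few compounds, and the source may have more. Where it says the series, first, only, none or still open, it means among the compounds named here.

Two compounds of this series carry numbers in a functional assay on CHO-K1 cells for antagonist activity at melanin-concentrating hormone receptor 1 (Homo sapiens), read by inositol phosphate accumulation, with stated times of 10 min and 45 min; on this read-out lower numbers stand for stronger inhibition and higher numbers for weaker inhibition. Compound 1 `Cc1nc(N(C)C2CCCC2)nc2ccc(NC(=O)/C=C/c3ccc(Cl)cc3)cc12` gives 57 nM in this assay, the lowest of the two numbers shown. Compound 2 `Cc1nc(N2CCC(O)(C3CC3)CC2)nc2ccc(NC(=O)/C=C/c3ccc(C(F)(F)F)cc3)cc12` gives 83 nM in this assay; the two values lie within the scatter of each other, so no order between compound 1 and compound 2 can be stated. Compound 2 also carries a different substituent on the cinnamoyl aryl ring, so its pair with compound 1 is not a single-point step.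

Compound 3 `CCCC1(O)CCN(c2nc(C)c3cc(NC(=O)/C=C/c4ccc(Cl)cc4)ccc3n2)CC1` is not yet measured. It differs from compound 1 by 4-hydroxy-4-propylpiperidin-1-yl in place of cyclopentyl(methyl)amino on an aromatic carbon. Within the data shown here, no measured single-point step of this kind exists, and the only related compound, compound 2, sits within the scatter of compound 1 in this assay. The step from compound 1 to compound 3 is therefore expected to be small, a 1.2-fold higher number from compound 1 to compound 3 (0.09 log units; within the scatter), with no direction beyond the scatter. Compound 3 is estimated at 70 nM in this assay, in a range from 25 nM to 200 nM.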

Compound 3, half-maximal inhibitory concentration: 91 nM
Compound 3: middle estimate off by 1.3-fold (0.11 log units), on the low side; the measured number falls inside the stated range.
By their numbers in this assay, from the lowest: compounds 1, 2 and 3 (each within the scatter of the next).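

Among these compounds, the step at this position is the first that can be read: in this assay, 4-hydroxy-4-propylpiperidin-1-yl in place of cyclopentyl(methyl)amino gives a 1.6-fold higher number from compound 1 to compound 3 (0.20 log units; within the scatter) and so separates the two groups by no more than the scatter. On the aromatic carbon between two ring nitrogen atoms, the shared core therefore tolerates a change from 7 to 10 heavy atoms, from a five-membered carbon ring to a six-membered ring with 1 hetero atom, and from 0 to 1 hydrogen-bond donor. Nothing at hand bears on why the number stays within the scatter.

Still open, as far as these compounds go, is how the hydroxy group and the propyl chain each contribute, which a 4-propylpiperidin-1-yl or a 4-hydroxypiperidin-1-yl at this carbon would separate. A basic amine, such as 4-aminopiperidin-1-yl, or a carboxylic acid on the piperidine ring also remains to be placed against these numbers.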